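From pyridin-2-yl to quinolin-2-yl in compound 2

The source may hold more compounds than are shown below. What is called first, only, known or untested is meant among the compounds shown, and "the series" means these compounds.

In a physicochemical assay for lipophilicity (on this read-out lower numbers stand for lower lipophilicity and higher numbers for higher lipophilicity), compound 2 (`CN(C)c1ccc(C(=O)OCC2(CO)C/C(=C\c3ccccn3)C(=O)O2)cc1`) gives 2.07 and stands lowest of the three measured compounds. Compound 1 (`CCCC(CCC)C(=O)OCC1(CO)C/C(=C/c2ccncc2)C(=O)O1`) gives 2.9 and compound 3 (`CN(C)c1ccc(C(=O)OCC2(CO)C/C(=C/c3ccc4ccccc4n3)C(=O)O2)cc1`) gives 3.22 and both lie above it, beyond the scatter. Compound 4 (`CN(C)c1ccc(C(=O)OCC2(CO)C/C(=C\c3ccc4ccccc4n3)C(=O)O2)cc1`), still unmeasured, has quinolin-2-yl in place of pyridin-2-yl on a double-bonded chain carbon bound to a double-bonded ring carbon. Going by the values given here, no measured pair differs in one place only, but compound 3, which also carries quinolin-2-yl, stands at 3.22 and so points upward. A rise beyond the scatter is expected in this assay with a number 1.13 log units higher from compound 2 to compound 4 (beyond the scatter) as the estimated step. For compound 4 the estimated value is 3.2 with an expected range of 2.8 to 3.6 on this scale.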

Compound 4, partition coefficient: 3.22
Beside the measured number, compound 4's estimate is 0.02 log units below it, and the stated range covers the measured number.
By their numbers in this assay, from the lowest: compound 2; then compound 1; then compounds 3 and 4 (each within the scatter of the next).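

In this assay, this position now has its first step that changes one place only: quinolin-2-yl in place of pyridin-2-yl gives a number 1.15 log units higher from compound 2 to compound 4 (beyond the scatter). Swapping the drawn double-bond geometry gives no change at the digits printed from compound 3 to compound 4 (within the scatter), so this read-out separates the two drawings by nothing. That reading carries one caution: the fact that one of compounds 3 and 4 is drawn with a defined configuration and the other without, at the place where they differ

From the compounds shown here alone, whether an amine or a carboxylic acid in place of quinolin-2-yl on the double-bonded chain carbon would shift the number as far stays open. So does whether the step would hold on another core.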